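Amide substituent variation on the shared core

The source may report more compounds than this note shows. Statements on the series, on what has been measured and on what is new or still open speak of the compounds shown alone.

Compound 1 `O=C(Nc1nc(-c2ccccc2)nc2c1nnn2Cc1ccccc1)C1CCCC1` gives 4690 nM in an assay on CHO cells for displacement of a labelled ligand from adenosine receptor A3 (Homo sapiens), read by scintillation counting; a lower number here means a stronger inhibitor, a higher number a weaker inhibitor.
Compound 2 `O=C(Nc1nc(-c2ccccc2)nc2c1nnn2Cc1ccccc1)c1ccc(Cl)cc1` gives 3550 nM in this assay.

Compound 2 shows the lower of the two numbers, but a 1.3-fold lower number from compound 1 to compound 2 (0.12 log units; within the scatter) places that gap within the scatter. Compound 3 `O=C(Nc1nc(-c2ccccc2)nc2c1nnn2Cc1ccccc1)c1cccc(C(F)(F)F)c1` differs from compound 2 by 3-(trifluoromethyl)phenyl in place of 4-chlorophenyl on a carbonyl carbon. Among the measured compounds shown here, the only measured step, a 1.3-fold lower number from compound 1 to compound 2 (0.12 log units; within the scatter), exchanged an aliphatic amide for an aromatic one without moving the number beyond the scatter; no step between two aryl amides has been measured. No change beyond the scatter is therefore expected in this assay, and compound 3 is estimated at 3200 nM (range 1100 nM to 9500 nM), an expected step of a 1.1-fold lower number from compound 2 to compound 3 (0.05 log units; within the scatter).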

Compound 3, inhibition constant: 2510 nM
Compound 3: middle estimate off by 1.3-fold (0.11 log units), on the high side, and the stated range covers the measured number.
By their numbers in this assay, from the lowest: compounds 3, 2 and 1 (each within the scatter of the next).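

With a 1.4-fold lower number from compound 2 to compound 3 (0.15 log units; within the scatter) in this assay the series now has a step between two aryl amides, and 3-(trifluoromethyl)phenyl on the carbonyl carbon is not told apart from 4-chlorophenyl. With a 1.9-fold lower number from compound 1 to compound 3 (0.27 log units; within the scatter) the aliphatic cyclopentyl amide is not told apart from this aryl amide either, so the three groups at this position give numbers that cannot be separated.

From the compounds shown here alone, whether an aryl amide carrying an amine or a carboxylic acid would move the number beyond the scatter stays open. No measured evidence bears on why these numbers lie so close.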